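The compounds below may be only part of what the source reports. "The series", "measured", "known", "first", "only" and "open" are said of these compounds alone.

In a functional assay on KB cells (Homo sapiens) for inhibition (a higher number here means a weaker inhibitor, a lower number a stronger inhibitor), compound 1 `N#C/N=C(\N)c1cn([C@@H]2O[C@H](CO)[C@@H](O)[C@H]2O)c2nnnc(N)c12` gives 5000 nM and compound 2 `N=C(NN)c1cn([C@@H]2O[C@H](CO)[C@@H](O)[C@H]2O)c2nnnc(N)c12` gives 3000 nM. These two numbers lie close together, as a 1.7-fold lower number from compound 1 to compound 2 (0.22 log units; within the scatter) shows, so compound 2 stands nearest to compound 1. Compound 3 `NC(=O)c1cn([C@@H]2O[C@H](COC(=O)c3ccccc3)[C@@H](OC(=O)c3ccccc3)[C@H]2OC(=O)c2ccccc2)c(N)c1C(N)=O` gives a limit of the assay, > 10000 nM, and not a number. Compound 4 `NC(=S)c1cn([C@@H]2O[C@H](CO)[C@@H](O)[C@H]2O)c2nnnc(N)c12` departs from compound 2 at one place: a group of 3 heavy atoms (1 carbon, 1 nitrogen, 1 sulfur; no ring) in place of a group of 4 heavy atoms (1 carbon, 3 nitrogen; no ring), on an aromatic carbon. For the measured compounds named here, the one measured step at this place is a 1.7-fold lower number from compound 1 to compound 2 (0.22 log units; within the scatter), and it involves no sulfur, so it offers only loose guidance. No step beyond the scatter is therefore expected in this assay. The estimated step is no change at the digits printed from compound 2 to compound 4 (within the scatter). Compound 4 is expected at about 3000 nM, with an estimated range of 500 nM to 10000 nM.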

Compound 4, half-maximal inhibitory concentration: 2000 nM
Beside the measured number, compound 4's estimate is 1.5-fold (0.18 log units) above it; low and high end bracket the measured number.
By their numbers in this assay, from the lowest: compounds 4, 2 and 1 (each within the scatter of the next, the first and the last beyond it). At a limit, above all of these: compound 3.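

In this assay, a group holding sulfur on this aromatic carbon gives a 1.5-fold lower number from compound 2 to compound 4 (0.18 log units; within the scatter), so it holds the level of the group it replaces. Against the group of 5 heavy atoms, the same place shows a 2.5-fold lower number from compound 1 to compound 4 (0.40 log units; beyond the scatter), the first step here beyond the scatter, though a modest one. Nothing measured here accounts for either step. Going by these compounds, it remains open whether a carboxylic acid or an amine on this carbon would shift the number further. Also open, on these data alone, is whether a carboxamide, with oxygen in place of the sulfur, would stay level with compound 4.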